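Shortening the ether chain of compound 1 by one carbon

The compounds below may be only part of what the source reports. "The series", "measured", "known", "first", "only" and "open" are said of these compounds alone.

Measured so far in a functional assay on PC-3 cells (Homo sapiens) for antiproliferative activity, read by sulforhodamine B assay, with a stated time of 3 days; a higher number here means that more compound is needed for the effect, a lower number that less compound is needed:
- compound 1 `CCCOC1=C(CCC)C(=O)/C(=C(O)/C=C/c2ccccc2)C(=O)C1(CCC)CCC`: 8.6 uM
- compound 2 `CCCC1(CC=C(C)C)C(=O)C(C(=O)/C=C/c2ccccc2)=C(O)C(CCC)(CCC)C1=O`: 8.4 uM
- compound 3 `COC1=C(CC=C(C)C)C(=O)/C(=C(O)/C=C/c2ccccc2)C(=O)C1(CC=C(C)C)CC=C(C)C`: 12.2 uM

Compound 1 stands second highest of the three numbers. Its nearest neighbour is compound 2, whose number lies within the scatter of compound 1; compound 3, the furthest, is also within the scatter. For the measured compounds named here, on these numbers the three compounds cannot be told apart, and no pair that differs in one place has been measured, so no step size is known from this set.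

Compound 4 `CCCC1=C(OCC)C(CCC)(CCC)C(=O)/C(=C(O)\C=C\c2ccccc2)C1=O` is yet to be measured in this assay. Against compound 1 the change is hydrogen in place of methyl on a saturated chain carbon, two bonds along the chain from an oxygen on an unsaturated carbon. The measured compounds differ from one another in several places at once and still sit within the scatter of one another, which gives no indication that a change of this size would move the number much.

The expected step is therefore small, in no clear direction, and not beyond the scatter. Compound 4 is expected to give 8.5 uM, with a range from 4.5 uM to 16 uM, which means a step of a 1.0-fold lower number from compound 1 to compound 4 (0.01 log units; within the scatter) that stays within the scatter.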

Compound 4, concentration for half-maximal effect: 12.5 uM
Estimate against measurement, compound 4: 1.5-fold (0.17 log units) below, within the range that was stated.
By their numbers in this assay, from the lowest: compounds 2, 1, 3 and 4 (each within the scatter of the next).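

In this assay, for the compounds shown here, propoxy to ethoxy gives the first step in this set that can be read for a single place, and it leaves compound 4 not distinguishable from compound 1 (a 1.5-fold higher number from compound 1 to compound 4 (0.16 log units; within the scatter)). Hydrogen in place of methyl on this saturated chain carbon, two bonds along the chain from an oxygen on an unsaturated carbon, therefore has a measured size for this one pair, where the earlier compounds, which differ in several places at once, gave none. The reading holds for this single pair on the core of compound 1 and cannot be extended to other chains on that core, and no measurement of any property of the two compounds accompanies the result, so the step stands without an explanation.

The compounds shown leave open whether the ether chain can be taken further in either direction, for example to a butoxy group or a longer chain, or replaced by a hydroxyl or an amine, without a step beyond the scatter. They also leave open whether the same shortening of a propyl chain elsewhere on the core would give a step of similar size.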